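The source may report more compounds than this note shows. Statements on the series, on what has been measured and on what is new or still open speak of the compounds shown alone.

In a functional assay on Bel-7402 cells (Homo sapiens) for inhibition, read by MTT assay, with a stated time of 24 h, tested at 100 ug/mL (a higher number here means more inhibition of growth at the concentration tested, a lower number less inhibition of growth), compound 3 (`CC(=O)SCCC(CCCCC(=O)Nc1ccccc1)SC(C)=O`) gives 14.1% and lies within the scatter of compound 2 (`O=C(CCCCC(S)CCS)Nc1cccc(Cl)c1`) at 16.1% in the same measurement. Both fall far short of compound 1 (`O=C(O)CCCCC(CCSC(=O)c1ccccc1)SC(=O)c1ccccc1`) at 81% in this test, a gap beyond the scatter. Going by the values given here, compound 4 (`CC(=O)SCCC(CCCCC(=O)Nc1ccc(Cl)cc1)SC(C)=O`) departs from compound 3 by chloro in place of hydrogen on an aromatic carbon as its only change: chloro in place of hydrogen on an aromatic carbon, para to a large group. Among the compounds with values here, no measured pair isolates this change. Compound 2 also carries a chloro group, and its 16.1% stays within the scatter of compound 3. The expected step of a number 2.9 percentage points higher from compound 3 to compound 4 (within the scatter) is therefore small, with no change beyond the scatter of this assay anticipated. Compound 4 is estimated at 17% with an expected range from 7% to 32% in this measurement.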

Compound 4, percent growth inhibition at one concentration: 45.5%
Beside the measured number, compound 4's estimate is 28.5 percentage points below it, outside the stated range (above it).
By their numbers in this assay, from the lowest: compounds 3 and 2 (each within the scatter of the next); then compound 4; then compound 1.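

In this assay, chloro in place of hydrogen on an aromatic carbon, para to a large group, gives a large step: a number 31.4 percentage points higher from compound 3 to compound 4 (beyond the scatter) with nothing else changed. Going by these compounds alone, this one position on the six-membered aromatic ring therefore matters in this test, which no earlier pair could show. No measurement given here explains the size of this step.

From the compounds shown here alone, whether fluoro, bromo or methoxy at the same position would give a comparable step stays open. So does whether chloro elsewhere on that ring would do so.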